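A few compounds are considered here, and "the series" means these few. Any claim that something is new, unique, unknown or untested is made for them only; others in the source may bear on it.

Compound 1 `C[C@@H](O)[C@H]1C(=O)N2C(C(=O)OCOC(=O)C(C)(C)C)=C(S[C@@H]3CN[C@H](C(=O)Nc4cccc(C(=O)O)c4)C3)[C@H](C)[C@H]12` in a physicochemical assay for metabolic stability, read by LC-MS, in phosphate buffer, with a stated time of 3 h, at pH 7.4, tested at 50 uM (on this read-out lower numbers stand for a less stable compound and higher numbers for a more stable compound), gives > 95%, which is a limit of the assay rather than a number.
Compound 2 `CCOC(=O)C1=C(S[C@@H]2CN[C@H](C(=O)Nc3cccc(C(=O)O)c3)C2)[C@H](C)[C@@H]2[C@@H]([C@@H](C)O)C(=O)N12` in this assay gives > 95%, again a limit of the assay.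
Compound 3 `C[C@@H](O)[C@H]1C(=O)N2C(C(=O)OCC(F)(F)F)=C(S[C@@H]3CN[C@H](C(=O)Nc4cccc(C(=O)O)c4)C3)[C@H](C)[C@H]12` in this assay gives > 95%, also a limit of the assay.

Compound 3 therefore stands at the upper limit of this assay, where all three measured compounds sit (the limit of > 95% in this assay, at which 3 of the 3 values shown sit). Compound 4 `CCOC(=O)OCOC(=O)C1=C(S[C@@H]2CN[C@H](C(=O)Nc3cccc(C(=O)O)c3)C2)[C@H](C)[C@@H]2[C@@H]([C@@H](C)O)C(=O)N12` is not yet measured; it differs from compound 3 in one place: (ethoxycarbonyl)oxy in place of trifluoromethyl on a saturated chain carbon bound to an oxygen next to a carbonyl group. The measured steps that bear on this change all exchange the group at the same position: a step that the two limits leave unreadable from compound 1 to compound 3, a step that the two limits leave unreadable from compound 2 to compound 3 and a step that the two limits leave unreadable from compound 1 to compound 2. None of these gives a readable size; every measured value is a limit (the limit of > 95% in this assay, at which 3 of the 3 values shown sit). So the three exchanges at this position, from a methyl through a trifluoromethyl to a ((tert-butyl)carbonyl)oxy group, left no visible change in this assay. On that basis, compound 4 is expected to remain near the limit, with a step of about a number at least 3 percentage points lower from compound 3 to compound 4 (that floor lies within the scatter) from compound 3, which is within the usual scatter. The estimate for compound 4 in this assay is 92%, expected to fall between 80% and 100%.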

Compound 4, percent of the compound remaining: > 95%
Compound 4: a limit, no number; the forecaster's own chance of this, stated with the estimate: 65%; middle value at least 3 percentage points from the limit.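

In this assay compound 4 gives > 95% as a limit of the assay, not a number. Among the compounds shown here, no step linking compound 4 with compound 1, compound 2 or compound 3 can be read. From the compounds shown here alone, whether these four compounds differ in stability at all, and by how much, stays open.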